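This account rests on a few compounds, and the source may have more. Where it says the series, first, only, none or still open, it means among the compounds named here.

Compound 3 `COc1ccccc1C(=O)Nc1ccc2[nH]cc(C3CCN(C)CC3)c2n1` carries a 2-methoxyphenyl on the carbonyl carbon of an amide attached to the shared core. In an assay for binding affinity to 5-hydroxytryptamine receptor 1F (Homo sapiens), read by radioligand binding (on this read-out higher numbers stand for weaker inhibition and lower numbers for stronger inhibition), compound 3 gives 20 nM, the second highest of the three numbers at hand. Its nearest neighbour is compound 1 `CN1CCC(c2c[nH]c3cnc(NC(=O)c4ccc(F)cc4)cc23)CC1`, which in this assay gives 13 nM, a gap that lies within the scatter. The furthest is compound 2 `CC(=O)Nc1cc2c(C3CCN(C)CC3)c[nH]c2cn1`, which gives 210 nM, well beyond the scatter from compound 3. Going by the values given here, the one single-point step among the measured compounds, a 16-fold higher number from compound 1 to compound 2 (1.21 log units; beyond the scatter), shows that replacing an aryl ring on the carbonyl carbon with a methyl costs a great deal.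

Compound 4 `CN1CCC(c2c[nH]c3ccc(NC(=O)c4ccc([N+](=O)[O-])cc4)nc23)CC1` differs from compound 3 in one place: 4-nitrophenyl in place of 2-methoxyphenyl on a carbonyl carbon. Among the compounds with values here, no measured step swaps one aryl ring for another, so the closest guidance is that compound 1 and compound 3, both with an aryl on the carbonyl carbon, sit within the scatter of each other, while only the loss of the aryl ring in compound 2 moves the number far. A 4-nitrophenyl keeps the aryl ring, so the expected step of no change at the digits printed from compound 3 to compound 4 (within the scatter) is small, in no clear direction beyond the scatter. Compound 4 is therefore estimated at 20 nM, in a range from 7 nM to 60 nM.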

Compound 4, inhibition constant: 7.7 nM
Estimate against measurement, compound 4: 2.6-fold (0.41 log units) above; the measured number falls inside the stated range.
By their numbers in this assay, from the lowest: compounds 4, 1 and 3 (each within the scatter of the next, the first and the last beyond it); then compound 2.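

In this assay, the change of 2-methoxyphenyl to 4-nitrophenyl on the carbonyl carbon gives a 2.6-fold lower number from compound 3 to compound 4 (0.41 log units; beyond the scatter). Going by these compounds alone, this is the first measured step that swaps one aryl ring for another, and it shows that the read-out at this place depends on more than whether an aryl ring is present: it also shifts, beyond the scatter, with what the ring carries, whereas the only earlier step, a 16-fold higher number from compound 1 to compound 2 (1.21 log units; beyond the scatter), removed the ring altogether and on a different core. Nothing at hand explains why the 4-nitrophenyl gives the lower number.

The step changes both the substituent and its place on the ring at once, so the compounds shown leave open which of the two accounts for the shift. A bare phenyl on the same carbonyl carbon would give a reference for both rings, and a phenyl ring carrying an amine or a carboxylic acid would show how far the number moves with other substituents on the ring.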